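A few compounds are considered here, and "the series" means these few. Any claim that something is new, unique, unknown or untested is made for them only; others in the source may bear on it.

Compound 1 `CCOC(=O)c1cnn(CC(C)O)c1NC(=O)NCc1ccccc1` (0.00054 nM)
Compound 2 `CCOC(=O)c1cnn(C)c1NC(=O)NCc1ccccc1` (1.3 nM)
Compound 3 `CCCC(O)Cn1ncc(C(=O)OCC)c1NC(=O)NCc1ccccc1` (0.0032 nM)

These values come from a functional assay on cells (Neutrophil, Homo sapiens) for inhibition, with a stated time of 10 min (a higher number here means a weaker inhibitor, a lower number a stronger inhibitor), and compound 2 has the highest number (1.3 nM), which makes it the weakest inhibitor of the three. Compound 4 `CCOC(=O)c1cnn(C)c1NC(=O)NC(C)C` keeps the core of compound 2 but has isopropyl in place of benzyl on an amide-type nitrogen.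

Among the measured compounds shown here, no measured step changes that place. All three alter the group on a saturated chain carbon bound to an aromatic nitrogen, so they offer only a rough sense of how far numbers can move in this small set. The steps of a 2400-fold higher number from compound 1 to compound 2 (3.38 log units; beyond the scatter) and a 410-fold lower number from compound 2 to compound 3 (2.61 log units; beyond the scatter) are large, while a 5.9-fold higher number from compound 1 to compound 3 (0.77 log units; beyond the scatter) is modest. None of them gives a direction for the new change, so the expectation is a tentative one: a moderate rise from compound 2 (1.3 nM), with wide uncertainty. The expected size is a 7.7-fold higher number from compound 2 to compound 4 (0.89 log units; beyond the scatter) in this assay and remains a judgement. Compound 4 is estimated at 10 nM (expected range 0.5 nM to 200 nM).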

Compound 4, half-maximal inhibitory concentration: 0.0018 nM
For compound 4 the middle estimate is 5600-fold (3.74 log units) above the measured one, and the stated range ends above it.
By their numbers in this assay, from the lowest: compound 1; then compounds 4 and 3 (each within the scatter of the next); then compound 2.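

Changing the group on the amide-type nitrogen gives a 720-fold lower number from compound 2 to compound 4 (2.86 log units; beyond the scatter) in this assay, so this place can move the number as strongly as the large steps seen on the chain at the aromatic nitrogen. The benzyl group with its aromatic ring is therefore not needed for a very low number on this core, since isopropyl, which is smaller and has no ring, does far better here. Nothing measured here explains why this swap lowers the number so much.

On these data alone, whether isopropyl would bring a similar drop on a compound that also carries a hydroxyl-bearing chain, such as compound 1, remains open. So does the effect of other groups on this nitrogen, such as cyclohexyl, a longer chain like n-butyl, or an ethyl group, and one step cannot separate the loss of the ring from the loss of size.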